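The source may hold more compounds than are shown below. What is called first, only, known or untested is meant among the compounds shown, and "the series" means these compounds.

Three compounds share one core and differ only in the group carried by the amide at its side. Compound 1 `CCCSc1nc(Cl)c2c(n1)N(Cc1ccccc1)C(C(=O)N1CCN(C(=O)OC(C)(C)C)CC1)N2` gives 32000 nM in a functional assay on MGC-803 cells (Homo sapiens) for antiproliferative activity, read by MTT assay, with a stated time of 72 h; on this read-out lower numbers stand for stronger inhibition and higher numbers for weaker inhibition. Compound 2 `CCCSc1nc(Cl)c2c(n1)N(Cc1cccs1)C(C(=O)N1CCN(C)CC1)N2` gives 62300 nM in this assay. Compound 3 `CCCSc1nc(Cl)c2c(n1)N(Cc1ccccc1)C(C(=O)NCCC1=CCc3ccccc31)N2` gives 27000 nM in this assay, the lowest of the three numbers; its gap to compound 1 lies within the scatter of repeated measurements, so those two cannot be told apart, while its gap to compound 2 lies beyond the scatter.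

Compound 4 `CCCSc1nc(Cl)c2c(n1)N(Cc1ccccc1)C(C(=O)NCC(C)C)N2` has not yet been measured. It differs from compound 3 by a group of 3 heavy atoms (3 carbon; no ring) in place of a group of 10 heavy atoms (10 carbon; one five-membered non-aromatic ring of carbon only, one six-membered aromatic ring of carbon only), on a saturated chain carbon bound to an amide-type nitrogen. Going by the values given here, no measured pair shows the effect of such a change, so the expectation rests only on the spread seen across compounds 1, 2 and 3, where different amide groups gave numbers that all stay weak and close together. A step from compound 3 to compound 4 of a 1.6-fold higher number from compound 3 to compound 4 (0.19 log units; within the scatter) is therefore expected, toward a somewhat higher number, though possibly not beyond the scatter. Compound 4 is estimated to give 42000 nM in this assay, with a range from 15000 nM to 110000 nM.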

Compound 4, half-maximal inhibitory concentration: 58400 nM
Estimate against measurement, compound 4: 1.4-fold (0.14 log units) below, and the stated range covers the measured number.
By their numbers in this assay, from the lowest: compounds 3, 1, 4 and 2 (each within the scatter of the next, the first and the last beyond it).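

In this assay, putting isopropyl in place of the group of 10 heavy atoms, on a saturated chain carbon bound to an amide-type nitrogen, gives a 2.2-fold higher number from compound 3 to compound 4 (0.34 log units; beyond the scatter). Going by these compounds alone, this is the first step here in which a single change can be followed, and it shows that the group at this place affects the number, since the step lies beyond the scatter. The step is modest, however, for a change that removes both rings and the double bond outside the aromatic ring, and nothing measured alongside it says what lies behind it.

The change removes the rings and shortens the group in one move, so the compounds shown leave open whether the rings, the size of the group or both account for the step. A longer straight carbon chain in place of isopropyl would speak to size alone, while a phenyl ring on the same chain would keep one ring and could show how far that ring alone carries the lower number of compound 3.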